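The compounds below may be only part of what the source reports. "The series", "measured", "known", "first", "only" and "open" are said of these compounds alone.

Measured in a functional assay on MT4 cells (Homo sapiens) for cytotoxicity; on this read-out lower numbers stand for higher toxicity in this test and higher numbers for lower toxicity in this test:

- Compound 1 `CC(C)Sc1nc(O)cc(C(C)c2c(F)cccc2F)n1`: 167000 nM
- Compound 2 `CCCCSc1nc(O)cc(C(C)c2c(F)cccc2F)n1`: > 200000 nM, a limit of the assay and not a number
- Compound 3 `Cc1c(O)nc(SC(C)C)nc1C(C)c1c(F)cccc1F`: 200000 nM

Only compound 1 and compound 3 have exact numbers in this assay, and those two lie within the scatter of each other. Compound 3 gives 200000 nM, and the methyl in place of hydrogen on an aromatic carbon that separates it from compound 1 amounts to a 1.2-fold higher number from compound 1 to compound 3 (0.08 log units; within the scatter).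

The next compound, compound 4 `CCCCSc1nc(O)c(C)c(C(C)c2c(F)cccc2F)n1`, has not yet been measured. It differs from compound 3 by butyl in place of isopropyl on a sulfur, with butyl in place of isopropyl on a sulfur. The same replacement has been measured once before, as an at least 1.1-fold higher number from compound 1 to compound 2 (0.07 log units; that floor lies within the scatter). That step is the direct precedent, but one of its ends is a limit, so it gives only a floor and no exact size. The methyl step from compound 1 to compound 3 is a different change, and it shows that the methyl-bearing compound 3 sits with compound 1 within the scatter.

No step beyond the scatter is therefore expected in this assay. Compound 4 may also return only a limit, as set out in the limit of > 200000 nM in this assay, at which 1 of the 3 values shown sits. The expected change is a 1.1-fold higher number from compound 3 to compound 4 (0.02 log units; within the scatter). For compound 4 the estimated value is 210000 nM, with an expected range of 130000 nM to 320000 nM.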

Compound 4, half-maximal cytotoxic concentration: 112000 nM
Beside the measured number, compound 4's estimate is 1.9-fold (0.27 log units) above it; measured number below the stated range.
By their numbers in this assay, from the lowest: compounds 4, 1 and 3 (each within the scatter of the next).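

Butyl in place of isopropyl on the sulfur now has an exact size in this assay, a 1.8-fold lower number from compound 3 to compound 4 (0.25 log units; within the scatter), where the earlier pair gave only a floor, and it stays inside the usual scatter on the methyl-bearing core. Methyl in place of hydrogen on an aromatic carbon can now also be read with butyl on the sulfur, as an at least 1.7-fold lower number from compound 2 to compound 4 (0.25 log units; that floor lies within the scatter), and that floor likewise lies within the scatter. Each change has now been seen on two cores, yet the butyl change gives no evidence of a real dependence on the core: the same change on two cores in this assay, an at least 1.1-fold higher number (0.07 log units; that floor lies within the scatter) from compound 1 to compound 2 and a 1.8-fold lower number (0.25 log units; within the scatter) from compound 3 to compound 4; the limit leaves it open whether they differ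

As far as these compounds go, the methyl change is just as unsettled, and the limit at compound 2 means that the true size of its step stays unknown: the same change on two cores in this assay, a 1.2-fold higher number (0.08 log units; within the scatter) from compound 1 to compound 3 and an at least 1.7-fold lower number (0.25 log units; that floor lies within the scatter) from compound 2 to compound 4; the limit leaves it open whether they differ All four compounds carry isopropyl or butyl on the sulfur, so it remains open how a longer chain such as octyl, a benzyl group or a chain ending in an amine at this position would read in this assay.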